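The source may hold more compounds than are shown below. What is called first, only, known or untested is meant among the compounds shown, and "the series" means these compounds.

Compound 1 `COc1cccc(Sc2c(NS(=O)(=O)c3ccc(C(C)(C)C)cc3)noc2CCCC#N)c1` gives 1300 nM in an assay on A7R5 cells for displacement of a labelled ligand from Endothelin-1 receptor (Rattus norvegicus); a lower number here means a stronger inhibitor, a higher number a weaker inhibitor.
Compound 2 `CSc1c(NS(=O)(=O)c2ccc(C(C)(C)C)cc2)noc1C` gives > 100000 nM in this assay, a limit of the assay.
Compound 3 `Cc1nsc(NS(=O)(=O)c2ccc(C(C)(C)C)cc2)c1C` gives > 500000 nM, again a limit of the assay.

Compound 1 is thus the only one of the three to give a number in this assay. The other two sit at limits, one at the limit of > 100000 nM in this assay, at which 1 of the 3 values shown sits, and one at the limit of > 500000 nM in this assay, at which 1 of the 3 values shown sits. Compound 4 `COc1cccc(Sc2c(NS(=O)(=O)c3ccc(C(C)(C)C)cc3)noc2CO)c1` has not been measured. It differs from compound 1 in one place: hydroxy in place of 2-cyanoethyl on a saturated chain carbon bound to an aromatic carbon. Going by the values given here, no measured pair shows this change, so the size of its step is open. Compound 4 is expected to stay near compound 1, with a step of a 1.9-fold higher number from compound 1 to compound 4 (0.28 log units; within the scatter) that may reach a little beyond the scatter, towards weaker binding. The estimate for compound 4 is 2500 nM, in the range 600 nM to 12000 nM.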

Compound 4, half-maximal inhibitory concentration: 6200 nM
Compound 4: middle estimate off by 2.5-fold (0.39 log units), on the low side; the measured number falls inside the stated range.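

Hydroxy in place of 2-cyanoethyl on a saturated chain carbon bound to an aromatic carbon gives the only measured step at this position: in this assay there is a 4.8-fold higher number from compound 1 to compound 4 (0.68 log units; beyond the scatter), a modest loss of binding. Compound 4 still gives a number rather than a limit of the assay, so binding survives the loss of the nitrile chain. Nothing measured here accounts for the size of this step. From the compounds shown here alone, whether an amine, a carboxylic acid or a longer chain ending in hydroxy would bind better or worse at this place stays open.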